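The compounds below may be only part of what the source reports. "The series", "measured", "known", "first", "only" and "open" are said of these compounds alone.

Compound 1 `CCCn1c(=O)[nH]c(=O)c2[nH]c(-c3cnn(Cc4ccccc4)c3)nc21`: in an assay on HEK293 cells for displacement of a labelled ligand from adenosine receptor A2b (Homo sapiens) (a higher number here means a weaker inhibitor, a lower number a stronger inhibitor), compound 1 gives > 6000 nM, a limit of the assay.
Compound 2 `CC(C)Cn1c(=O)[nH]c(=O)c2[nH]c(-c3cnn(Cc4ccccc4)c3)nc21`: in this assay compound 2 gives > 6000 nM, again a limit.
Going by the values given here, compound 3 `CCCn1c(=O)[nH]c2nc(-c3cnn(Cc4cccc(F)c4)c3)[nH]c2c1=O`: in this assay compound 3 gives 11 nM, the only number among the three.

The change from compound 1 to compound 2 is methyl in place of hydrogen on a saturated chain carbon bound to two saturated chain carbons. The step that the two limits leave unreadable from compound 1 to compound 2 is not readable, which rests on (the limit of > 6000 nM in this assay, at which 2 of the 3 values shown sit). The difference between the core of compound 1 and the core of compound 3 is not broken down here. Compound 4 `CC(C)Cn1c(=O)[nH]c2nc(-c3cnn(Cc4cccc(F)c4)c3)[nH]c2c1=O` carries the same change on the core of compound 3: methyl in place of hydrogen on a saturated chain carbon bound to two saturated chain carbons. The measured pair leaves the size of this change open. The step from compound 3 to compound 4 is therefore expected to be small, a 2.3-fold higher number from compound 3 to compound 4 (0.36 log units; beyond the scatter). Compound 4 is expected at 25 nM in this assay, between 6 nM and 150 nM.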

Compound 4, inhibition constant: 24 nM
The estimate for compound 4 lay 1.0-fold (0.02 log units) above the measured number, within the range that was stated.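

On the core of compound 3, methyl in place of hydrogen on a saturated chain carbon bound to two saturated chain carbons gives a 2.2-fold higher number from compound 3 to compound 4 (0.34 log units; beyond the scatter) in this assay. This gives the size of the change on that core only, so it neither confirms nor refutes that the change carries over from one core to another. The same change on the core of compound 1 cannot be read, as both compounds of that pair sit at a limit: the limit of > 6000 nM in this assay, at which 2 of the 4 values shown sit.

The compounds shown leave open how a longer chain, such as pentyl, would read on the core of compound 3. Going by these compounds, a chain ending in an amine or a carboxylic acid also remains open there.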